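Lengthening the sulfonamide chain of compound 1

The source may report more compounds than this note shows. Statements on the series, on what has been measured and on what is new or still open speak of the compounds shown alone.

- compound 1 `CCC1C(=O)N(C)c2cnc(Nc3ccc(S(=O)(=O)NC)cc3)nc2N1c1ccn(C)n1` at 2200 nM 
- compound 2 `CCC1C(=O)N(C)c2cnc(-n3ccc4cc(C(=O)NC(C)C)ccc43)nc2N1c1ccn(C)n1` at 4350 nM 

In a functional assay on HeLa cells (Homo sapiens) for antiproliferative activity, read by CCK-8 assay, with a stated time of 72 h (a lower number here means a stronger inhibitor of growth, a higher number a weaker inhibitor of growth), compound 1 and compound 2 lie within the usual scatter of each other, so compound 1 does not stand apart on these numbers. Compound 3 `CCCNS(=O)(=O)c1ccc(Nc2ncc3c(n2)N(c2ccn(C)n2)C(CC)C(=O)N3C)cc1` keeps the core of compound 1 and carries ethyl in place of hydrogen on a saturated chain carbon bound to a sulfonamide nitrogen, ethyl in place of hydrogen on a saturated chain carbon bound to a sulfonamide nitrogen, which turns methylsulfamoyl into propylsulfamoyl. Going by the values given here, no measured pair tests this change, so the anchor is compound 1 at 2200 nM and no shift beyond the scatter is expected in this assay. The expected step is a 1.1-fold higher number from compound 1 to compound 3 (0.06 log units; within the scatter) in size. For compound 3 the estimated value is 2500 nM, with an expected range of 1000 nM to 6000 nM.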

Compound 3, concentration for 50% growth inhibition: 2670 nM
Beside the measured number, compound 3's estimate is 1.1-fold (0.03 log units) below it, and the stated range covers the measured number.
By their numbers in this assay, from the lowest: compounds 1, 3 and 2 (each within the scatter of the next).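

Methylsulfamoyl to propylsulfamoyl gives a 1.2-fold higher number from compound 1 to compound 3 (0.08 log units; within the scatter) in this assay, the only one-place comparison in the series so far. At this position, then, ethyl in place of hydrogen on a saturated chain carbon bound to a sulfonamide nitrogen leaves growth inhibition unchanged within the scatter. No supporting data bear on why this is so.

Still open, from the compounds shown here alone, is whether a longer chain, a carboxylic acid or an amine at the end of this chain would separate from compound 1. One step also cannot show whether this tolerance extends to other chains.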